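Compound 2 to compound 3: 4-fluorophenyl to 4-chlorophenyl

The source may report more compounds than this note shows. Statements on the series, on what has been measured and on what is new or still open speak of the compounds shown alone.

Among the measured compounds shown here, in a functional assay on HeLa cells (Homo sapiens) for antiproliferative activity, read by MTT assay, with a stated time of 48 h (a lower number here means a stronger inhibitor, a higher number a weaker inhibitor), compound 2 `O=C(OCc1ccccc1)c1ccc2[nH]c(-c3cn(-c4ccccc4)nc3-c3ccc(F)cc3)nc2c1` gives 23600 nM, the highest of the two numbers so far. Compound 1 `Fc1ccc(-c2nn(-c3ccccc3)cc2-c2nc3cc(Cl)ccc3[nH]2)cc1` gives 2770 nM. For the measured compounds named here, the only measured step, an 8.5-fold higher number from compound 1 to compound 2 (0.93 log units; beyond the scatter), is benzyloxycarbonyl in place of chloro on an aromatic carbon, a change at another place on the structure. Compound 3 `O=C(OCc1ccccc1)c1ccc2[nH]c(-c3cn(-c4ccccc4)nc3-c3ccc(Cl)cc3)nc2c1` has chloro in place of fluoro on an aromatic carbon. Going by the values given here, no measured pair covers this exchange. Among the compounds with values here, the one measured step shows that the numbers can move beyond the scatter, but it gives neither a size nor a direction for this change. No shift beyond the scatter is therefore expected. The expected step is a 1.1-fold lower number from compound 2 to compound 3 (0.05 log units; within the scatter). For compound 3 the estimated value is 21000 nM, with an expected range from 9000 nM to 48000 nM.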

Compound 3, half-maximal inhibitory concentration: 8130 nM
Compound 3: middle estimate off by 2.6-fold (0.41 log units), on the high side; the whole stated range lies above it.
By their numbers in this assay, from the lowest: compound 1; then compound 3; then compound 2.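

Among the compounds shown here, the 4-fluorophenyl to 4-chlorophenyl exchange is the first measured change at this position, and a 2.9-fold lower number from compound 2 to compound 3 (0.46 log units; beyond the scatter) in this assay is the step it gives. The halogen on this ring, para to a large group, therefore matters in the benzyloxycarbonyl compounds: one atom exchanged moves the number beyond the scatter, towards a stronger inhibitor. Nothing available explains the difference between chloro and fluoro at this place.

On these data alone, it remains open whether the same exchange gives a step of similar size and direction when chloro replaces benzyloxycarbonyl on the core, as in compound 1. Also open, as far as these compounds go, is how other groups at this place, such as bromo, methoxy, an amine or a carboxylic acid, would compare with chloro.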